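The source may report more compounds than this note shows. Statements on the series, on what has been measured and on what is new or still open speak of the compounds shown alone.

Compound 1, `C=CCc1cc(-c2ccc(C(F)(F)F)cc2)ccc1O`, gives 76000 nM in a functional assay on A549 cells (Homo sapiens) for antiproliferative activity, read by MTT assay, with a stated time of 24 h; a higher number here means a weaker inhibitor, a lower number a stronger inhibitor. Compound 2, `C=CC(C)(C)c1cc(-c2ccc(OC)cc2)ccc1O`, reaches only the assay limit of > 100000 nM in this assay. Compound 3, `C=CCc1cc(-c2ccc(F)cc2)ccc1O`, likewise reaches only the assay limit of > 100000 nM in this assay.

Compound 3 thus stands at the limit of > 100000 nM in this assay, at which 2 of the 3 values shown sit, with no number of its own. Compound 4, `C=CCc1cc(-c2ccccc2)ccc1O`, differs from it by hydrogen in place of fluoro on an aromatic carbon. Among the measured compounds shown here, the only measured step that touches this position is an at least 1.3-fold higher number from compound 1 to compound 3 (0.11 log units; that floor lies within the scatter), a change too small to rise above the scatter. Compound 4 is therefore expected to shift by no more than the scatter, a step that the limit leaves unreadable from compound 3 to compound 4. Compound 4 is estimated at 120000 nM, in the range 60000 nM to 300000 nM, in this assay.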

Compound 4, half-maximal inhibitory concentration: > 100000 nM
Compound 4: a limit, no number (the forecaster's own chance of this, stated with the estimate: 65%); the middle value lies beyond the limit too.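

With hydrogen on this carbon, para to a large group, compound 4 also gives only a limit in this assay, so the change from fluoro cannot be read. Hydrogen in place of trifluoromethyl gives no separation beyond the scatter (an at least 1.3-fold higher number from compound 1 to compound 4 (0.11 log units; that floor lies within the scatter)). Among the compounds shown here, compound 1 remains the only compound here with a number, and the series now gathers at the ceiling: the limit of > 100000 nM in this assay, at which 3 of the 4 values shown sit.

On these data alone, it remains open whether an amine or a carboxylic acid on this carbon would give a value inside the limit. A longer chain in place of trifluoromethyl is equally untested by these compounds.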